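Pyrazole substituent swap in the glucagon antagonist series

The source may hold more compounds than are shown below. What is called first, only, known or untested is meant among the compounds shown, and "the series" means these compounds.

Compound 1 `CCCC(Oc1ccc(-n2cc(C(F)(F)F)cn2)c(C)c1)c1ccc(C(=O)NCCC(=O)O)cc1` gives 1900 nM in a functional assay on cells for antagonist activity at Glucagon receptor (Homo sapiens), read by cAMP accumulation, in the presence of a further agent that is not named here; a higher number here means a weaker inhibitor, a lower number a stronger inhibitor. Compound 2 `CCCC(Oc1ccc(-n2cc(C(=O)N(C)C)cn2)cc1)c1ccc(C(=O)NCCC(=O)O)cc1` reaches only a limit of this assay, > 30000 nM. Compound 2 thus sits at the limit of > 30000 nM in this assay, at which 1 of the 2 values shown sits, and only a range is known for it. Compound 3 `CCCC(Oc1ccc(-n2cc(C(F)(F)F)c(C)n2)cc1)c1ccc(C(=O)NCCC(=O)O)cc1` carries 3-methyl-4-(trifluoromethyl)-1H-pyrazol-1-yl in place of 4-(dimethylcarbamoyl)-1H-pyrazol-1-yl on an aromatic carbon. For the measured compounds named here, no measured step covers this change. Compound 1, which also carries a trifluoromethyl on its pyrazole, gives 1900 nM in this assay. On that ground the step of an at least 10-fold lower number from compound 2 to compound 3 (1.00 log units; beyond the scatter) is expected to run toward a lower number, beyond the scatter. Compound 3 is estimated at 3000 nM, within 800 nM to 15000 nM.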

Compound 3, antagonist equilibrium constant: 8300 nM
Compound 3: the middle estimate sits 2.8-fold (0.44 log units) below what was measured; the range from low to high includes it.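

Para to a large group, 3-methyl-4-(trifluoromethyl)-1H-pyrazol-1-yl in place of 4-(dimethylcarbamoyl)-1H-pyrazol-1-yl gives an at least 3.6-fold lower number from compound 2 to compound 3 (0.55 log units; beyond the scatter) in this assay. For the compounds shown here, this is the first readable step at this place, and it shows that the pyrazole substituents set the reading here. Compound 2 stands only at a limit, so the step gives a bound and not a full size: the limit of > 30000 nM in this assay, at which 1 of the 3 values shown sits.

The methyl and the trifluoromethyl enter together, so their separate shares remain unresolved. On these data alone, whether a nitrile or a carboxylic acid on the pyrazole would keep this reading also remains open.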